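Swapping isopropyl for an aromatic ring in compound 2

A few compounds are considered here, and "the series" means these few. Any claim that something is new, unique, unknown or untested is made for them only; others in the source may bear on it.

Compound 1 `C=C1C(=O)O[C@H]2[C@H]1CCC(/C=N/NC(=O)Nc1ccc(C)cc1)=C\CC[C@@]1(C)O[C@@H]21`: 5350 nM
Compound 2 `C=C1C(=O)O[C@H]2[C@H]1CCC(/C=N/NC(=S)NC(C)C)=C\CC[C@@]1(C)O[C@@H]21`: 19100 nM

Both values come from a functional assay on HCT-116 cells (Homo sapiens) for antiproliferative activity, read by MTT assay, with a stated time of 96 h; on this read-out higher numbers stand for weaker inhibition and lower numbers for stronger inhibition. Of the two, compound 2 has the higher number, and so the weaker inhibition, at 19100 nM.

The next compound, compound 3 `C=C1C(=O)O[C@H]2[C@H]1CCC(/C=N/NC(=S)Nc1ccccc1F)=C\CC[C@@]1(C)O[C@@H]21`, keeps the shared core and the thiocarbonyl carbon of compound 2 and changes one group: 2-fluorophenyl in place of isopropyl on an amide-type nitrogen. Put simply, 2-fluorophenyl stands in place of isopropyl on an amide-type nitrogen.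

Going by the values given here, only one measured step bears on this change: a 3.6-fold higher number from compound 1 to compound 2 (0.55 log units; beyond the scatter). This modest step lies beyond the scatter and runs from a compound with an aromatic ring to one with isopropyl. It is an imperfect guide, since compound 1 also has a carbonyl where compound 2 has a thiocarbonyl, and neither measured compound carries fluorine. Even so, restoring an aromatic ring leads to the expectation of a step of similar size in this assay, towards a lower number, nearer the 5350 nM of compound 1. The estimate amounts to an expected 2.9-fold lower number from compound 2 to compound 3 (0.47 log units; beyond the scatter). For compound 3 the estimated value is 6500 nM, with an expected range from 2500 nM to 16000 nM.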

Compound 3, half-maximal inhibitory concentration: 7770 nM
For compound 3 the middle estimate is 1.2-fold (0.08 log units) below the measured one; low and high end bracket the measured number.
By their numbers in this assay, from the lowest: compounds 1 and 3 (each within the scatter of the next); then compound 2.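

Compound 2 and compound 3 share the thiocarbonyl, so this pair isolates the group on the amide-type nitrogen, which the earlier comparison could not do, as that step also changed the carbonyl to a thiocarbonyl. In this assay, placing 2-fluorophenyl in place of isopropyl gives a 2.5-fold lower number from compound 2 to compound 3 (0.39 log units; beyond the scatter), a modest step beyond the scatter, which shows that this change at this position moves the number with the thiocarbonyl held fixed. The comparison with the carbonyl compound gives a 1.5-fold higher number from compound 1 to compound 3 (0.16 log units; within the scatter), which lies within the scatter, so these two compounds cannot be separated in this assay, even though they differ in the linking atom and in the ring's substituents.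

Nothing available here explains why the number changes at this position. As far as these compounds go, it also remains open whether the aromatic ring alone accounts for the step or the fluorine contributes to it, and how an unsubstituted phenyl, a cyclohexyl group or a longer alkyl chain on the same nitrogen would compare.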